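The source may hold more compounds than are shown below. What is called first, only, known or untested is meant among the compounds shown, and "the series" means these compounds.

Compound 3 `C=CC1=C(C(=O)O)C(c2ccc(OC)cc2)OC1` stands at the edge of what the assay reports. In a functional assay on A549 cells (Homo sapiens) for cytotoxicity, read by MTT assay, with a stated time of 24 h (a higher number here means a weaker inhibitor, a lower number a stronger inhibitor), compound 3 gives > 100000 nM, a limit rather than a number. Compound 1 `C=CC1=C(C(=O)NCc2ccccc2)C(c2ccc(OC)cc2)OC1` gives > 100000 nM, also a limit. Compound 2 `C=CC1=C(C(=O)O)C(c2ccc(F)cc2)OC1` gives > 100000 nM, again a limit. All three values sit at the limit of > 100000 nM in this assay, at which 3 of the 3 values shown sit, so a step that the two limits leave unreadable from compound 1 to compound 3 and a step that the two limits leave unreadable from compound 2 to compound 3 cannot be read. Compound 4 `C=CC1=C(C(=O)NC(C)(C)C)C(c2ccc(OC)cc2)OC1` differs from compound 3 by (tert-butyl)amino in place of hydroxy on a carbonyl carbon. For the measured compounds named here, the only earlier change at the carbonyl carbon, a step that the two limits leave unreadable from compound 1 to compound 3, gives no readable size, and no other measured step bears on this change. Compound 4 is therefore expected to stay at the limit, with a number no higher from compound 3 to compound 4 (the limit leaves the size open) as the estimated step. The estimate for compound 4 in this assay is 100000 nM, expected within 30000 nM to 300000 nM.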

Compound 4, half-maximal inhibitory concentration: > 100000 nM
Compound 4 ended at the assay's limit; the forecaster's own chance of this, stated with the estimate: 85%; the middle value sits exactly at the limit.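

No new step can be read for compound 4 against compound 3 or compound 1, since every value is a limit: the limit of > 100000 nM in this assay, at which 4 of the 4 values shown sit. The compounds shown leave open how far any of these changes moves cytotoxicity, as none gives a value inside the reported range.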